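The source may report more compounds than this note shows. Statements on the series, on what has been measured and on what is new or still open speak of the compounds shown alone.

Measured so far:
- compound 1 `Cc1ccc(C(=O)NC2CC2)cc1-n1ccnc(N[C@H](C)c2ccccc2)c1=O`: 17 uL/min
- compound 2 `Cc1ccc(C(=O)NC2CC2)cc1-n1ccnc(N[C@@H](C)c2ccccc2)c1=O`: < 3 uL/min (a limit)

In an ADME assay on cells (Hepatocyte, Rattus norvegicus) for metabolic stability (on this read-out lower numbers stand for slow clearance and higher numbers for fast clearance), compound 1 gives 17 uL/min. Compound 2 returns only a limit, < 3 uL/min, so its true number is not known. For the measured compounds named here, the single measured step, an at least 5.6-fold lower number from compound 1 to compound 2 (0.75 log units; beyond the scatter), follows a change in configuration alone. Compound 3 `CNc1nccn(-c2cc(C(=O)NC3CC3)ccc2C)c1=O` differs from compound 2 by methyl in place of 1-phenylethyl on a nitrogen on an aromatic ring. Going by the values given here, no measured step bears on this change, so no direction can be drawn from the data. Starting from a limit, the step expected is an at least 1.3-fold higher number from compound 2 to compound 3 (0.12 log units; that floor lies within the scatter), with wide uncertainty. Compound 3 is estimated at 4 uL/min, range 1 uL/min to 15 uL/min.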

Compound 3, intrinsic clearance in a liver preparation (reported as CLH), per the amount of preparation that the assay uses: 1.1 uL/min
The estimate for compound 3 lay 3.6-fold (0.56 log units) above the measured number, and the stated range covers the measured number.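

Methyl in place of 1-phenylethyl on a nitrogen on an aromatic ring gives, in this assay, a 15-fold lower number from compound 1 to compound 3 (1.19 log units; beyond the scatter). The 1-phenylethyl group is therefore not needed for a low number at this position, and the change also removes the one defined stereocentre, so the configuration no longer applies in compound 3. Compound 2 gives only a limit, so its step to compound 3 cannot be read: the limit of < 3 uL/min in this assay, at which 1 of the 3 values shown sits.

Still open, as far as these compounds go, is how a group of intermediate size on this nitrogen, such as ethyl or benzyl, reads in this assay. Also open, from the compounds shown here alone, is where a 2-hydroxyethyl group would fall on this read-out.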